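Indazole in place of cyanopyrazole on the aryl ether

The source may hold more compounds than are shown below. What is called first, only, known or untested is meant among the compounds shown, and "the series" means these compounds.

Measured so far:
- compound 1, `CCCC(Oc1ccc(-n2cc(F)cn2)cc1)c1ccc(C(=O)NCCC(=O)O)cc1`: 10000 nM
- compound 2, `CCCC(Nc1cc(C)c(-n2cc(C(F)(F)F)cn2)c(C)c1)c1ccc(C(=O)NCCC(=O)O)cc1`: 1400 nM
- compound 3, `CCCC(Oc1ccc(-n2cc(C#N)cn2)cc1)c1ccc(C(=O)NCCC(=O)O)cc1`: > 50000 nM

Compound 3 sits at the weak end of the series. In a functional assay on cells for antagonist activity at Glucagon receptor (Homo sapiens), read by cAMP accumulation, in the presence of a further agent that is not named here (a lower number here means a stronger inhibitor, a higher number a weaker inhibitor), compound 3 gives only a limit, > 50000 nM, and no number; this is the assay limit (the limit of > 50000 nM in this assay, at which 1 of the 3 values shown sits). Going by the values given here, the single measured step that reaches compound 3 is an at least 5.0-fold higher number from compound 1 to compound 3 (0.69 log units; beyond the scatter), so compound 1 stands clearly stronger than the limit of compound 3, and compound 2 stands stronger again on its own core.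

Compound 4 is `CCCC(Oc1ccc(-n2cc3ccccc3n2)cc1)c1ccc(C(=O)NCCC(=O)O)cc1`. It differs from compound 3 in one place: 2H-indazol-2-yl in place of 4-cyano-1H-pyrazol-1-yl on an aromatic carbon. Among the compounds with values here, no measured step describes this change, only the observation that going from fluoro to cyano on the pyrazole moved the number from compound 1 to the limit at compound 3. Removing the cyano and enlarging the ring is therefore expected to bring the number back toward the measured range, but without a comparable measured step the size is uncertain, and a limit remains a fair possibility. The expected value for compound 4 in this assay is 15000 nM, with a range from 3000 nM to 60000 nM, that is an estimated step of an at least 3.3-fold lower number from compound 3 to compound 4 (0.52 log units; beyond the scatter).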

Compound 4, antagonist equilibrium constant: 2000 nM
Estimate against measurement, compound 4: 7.5-fold (0.88 log units) above; the whole stated range lies above it.
By their numbers in this assay, from the lowest: compounds 2 and 4 (each within the scatter of the next); then compound 1. At a limit, above all of these: compound 3.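

In this assay, 2H-indazol-2-yl in place of 4-cyano-1H-pyrazol-1-yl gives an at least 25-fold lower number from compound 3 to compound 4 (1.39 log units; beyond the scatter), and in place of 4-fluoro-1H-pyrazol-1-yl it gives a 5.0-fold lower number from compound 1 to compound 4 (0.70 log units; beyond the scatter). Going by these compounds alone, compound 3 stands at a limit, so the first step fixes only a minimum size: the limit of > 50000 nM in this assay, at which 1 of the 4 values shown sits. The earlier compounds showed only a loss on changing the pyrazole substituent, whereas compound 4 shows that this position, on an aromatic carbon para to a large group, can carry an added six-membered aromatic ring of carbon only with a gain over both pyrazoles.

Still open, from the compounds shown here alone, is how an unsubstituted 1H-pyrazol-1-yl would read on this core, which would separate the effect of the added ring from that of the pyrazole substituent. Also open, going by these compounds, are whether a methoxy or an amine on the added ring moves the number further, and whether 2H-indazol-2-yl carries over to the core of compound 2.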